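The compounds below may be only part of what the source reports. "The series", "measured", "known", "first", "only" and "open" are said of these compounds alone.

Measured compounds in a functional assay on MCF7 cells (Homo sapiens) for cytotoxicity, read by MTT assay, with a stated time of 72 h; a lower number here means a stronger inhibitor, a higher number a weaker inhibitor:

- compound 1 `CN(C)CCCCCn1c2c(c3ccccc31)C(=O)c1c[n+]([O-])c3ccccc3c1C2=O`: compound 1 gives 200 nM
- compound 2 `O=C1c2c[n+]([O-])c3ccccc3c2C(=O)c2c1c1ccccc1n2Cc1cn(C[C@H](O)CO)nn1`: compound 2 reaches only a limit of the assay, > 1000 nM
- compound 3 `CC1(C)OC[C@@H](Cn2cc(Cn3c4c(c5ccccc53)C(=O)c3c[n+]([O-])c5ccccc5c3C4=O)nn2)O1`: compound 3 also sits at a limit of the assay, > 1000 nM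

Within the data shown here, compound 1 holds the only number; the other two values are the limit of > 1000 nM in this assay, at which 2 of the 3 values shown sit. Compound 4 `CN1CCN(CCCn2c3c(c4ccccc42)C(=O)c2c[n+]([O-])c4ccccc4c2C3=O)CC1` differs from compound 1 by 4-methylpiperazin-1-yl in place of 2-(dimethylamino)ethyl on a saturated chain carbon, three bonds along the chain from an aromatic nitrogen. Among the measured compounds shown here, the one readable step, an at least 5.0-fold higher number from compound 1 to compound 2 (0.69 log units; beyond the scatter), swapped the whole 4-(dimethylamino)butyl chain for a triazole carrying a diol, a change of another kind, and a step that the two limits leave unreadable from compound 2 to compound 3. For the measured compounds named here, no measured step cyclises the amine as this one does, so the change is uncharted. The step from compound 1 to compound 4 is expected to stay within the scatter, a 1.3-fold higher number from compound 1 to compound 4 (0.10 log units; within the scatter). Compound 4 is estimated at 250 nM, between 100 nM and 800 nM.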

Compound 4, half-maximal inhibitory concentration: 220 nM
Compound 4: middle estimate off by 1.1-fold (0.06 log units), on the high side, within the range that was stated.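

Swapping the 5-(dimethylamino)pentyl chain for 3-(4-methylpiperazin-1-yl)propyl gives a 1.1-fold higher number from compound 1 to compound 4 (0.04 log units; within the scatter), so at this position a chain amine closed into a ring and a dimethylamino chain read alike. The piperazine chain also stands clear of the triazole diol, with an at least 4.5-fold lower number from compound 2 to compound 4 (0.65 log units; beyond the scatter). Compound 2 sits at a limit of the assay, so that step is bounded on one side only: the limit of > 1000 nM in this assay, at which 2 of the 4 values shown sit.

Still open, going by these compounds, are a 3-(dimethylamino)propyl chain, which would separate ring closure from chain length, and a morpholine, which would replace the second ring nitrogen with oxygen.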